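A few compounds are considered here, and "the series" means these few. Any claim that something is new, unique, unknown or untested is made for them only; others in the source may bear on it.

Among the measured compounds shown here, compound 2 `O=C(Nc1ccccc1)N[C@H]1CC[C@H](Oc2ccc(F)cc2)CC1` is the only compound of this set with a true number: in a functional assay on CRL2813 cells (Homo sapiens) for cytotoxicity, read by sulforhodamine B assay, with a stated time of 5 days (a higher number here means a weaker inhibitor, a lower number a stronger inhibitor), compound 2 gives 20000 nM. Compound 1 `CSc1ccc(NC(=O)N[C@H]2CC[C@H](Oc3ccc(F)cc3)CC2)cc1` carries a methylsulfanyl group where compound 2 carries hydrogen, and in this assay compound 1 gives only a limit, > 20000 nM. For the measured compounds named here, the step of a number no higher from compound 1 to compound 2 (the limit leaves the size open) is the single measured step that touches this position, and because the limit of > 20000 nM in this assay, at which 1 of the 2 values shown sits, its size cannot be read. Compound 3 `COC(=O)c1ccc(NC(=O)N[C@H]2CC[C@H](Oc3ccc(F)cc3)CC2)cc1` has not yet been measured. It differs from compound 2 by methoxycarbonyl in place of hydrogen on an aromatic carbon. With one measured step of unreadable size at this position, nothing points to a change beyond the usual scatter. The estimate for compound 3 in this assay is 20000 nM, with a range from 8000 nM to 50000 nM. This estimate means a step of no change at the digits printed from compound 2 to compound 3 (within the scatter) that is expected to stay close to zero, and the result may again be only a limit.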

Compound 3, half-maximal inhibitory concentration: 11600 nM
For compound 3 the middle estimate is 1.7-fold (0.24 log units) above the measured one; the measured number falls inside the stated range.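

In this assay this position now has its first step of readable size, a 1.7-fold lower number from compound 2 to compound 3 (0.24 log units; within the scatter). Methoxycarbonyl, with its 4 heavy atoms and 2 hydrogen-bond acceptors, can therefore stand on this aromatic carbon, para to a large group, without moving the number beyond the scatter. The swap of methylsulfanyl for methoxycarbonyl gives an at least 1.7-fold lower number from compound 1 to compound 3 (0.23 log units; that floor lies within the scatter), but only a floor can be given for this step, and even that floor does not show a real difference, because one end of it is a limit: the limit of > 20000 nM in this assay, at which 1 of the 3 values shown sits.

The compounds shown leave open whether any group on this aromatic carbon can move the number beyond the scatter. A carboxylic acid, an amine or a longer chain in the same place would be a further test of that question.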